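Methyl on the piperidine ring of an inactive nitro sulfone amide

A few compounds are considered here, and "the series" means these few. Any claim that something is new, unique, unknown or untested is made for them only; others in the source may bear on it.

Measured so far in an assay on isolated protein for inhibition of thyroid hormone receptor beta (Homo sapiens), read by fluorescence polarization; a lower number here means a stronger inhibitor, a higher number a weaker inhibitor:
- compound 1 `CS(=O)(=O)c1ccc(C(=O)NCCC(=O)N2CCCCC2)cc1[N+](=O)[O-]`: > 60000 nM
- compound 2 `CC1CCN(C(=O)CN(C)C(=O)c2ccc(S(C)(=O)=O)c([N+](=O)[O-])c2)CC1`: > 60000 nM

Compound 1 gives only a limit of this assay, > 60000 nM. Compound 2 likewise gives only a limit, > 60000 nM. Neither value is a number, so compound 1 stands at the ceiling of what has been measured, as the limit of > 60000 nM in this assay, at which 2 of the 2 values shown sit, states.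

Compound 3 `CC1CCN(C(=O)CCNC(=O)c2ccc(S(C)(=O)=O)c([N+](=O)[O-])c2)CC1` differs from compound 1 by methyl in place of hydrogen on a saturated ring carbon. Among the measured compounds shown here, no step between measured compounds is available for this change. Given (the limit of > 60000 nM in this assay, at which 2 of the 2 values shown sit), the expected step that the limit leaves unreadable from compound 1 to compound 3 is none beyond the scatter, and compound 3 is expected most likely to return a limit again. Compound 3 is estimated at 80000 nM, with a range from 30000 nM to 300000 nM.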

Compound 3, half-maximal inhibitory concentration: > 60000 nM
Compound 3: only a limit was reported; the forecaster's own chance of this, stated with the estimate: 85%; the middle value lies beyond the limit too.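

Among the compounds shown here, compound 1 and compound 3 both return only a limit, so no step for piperidin-1-yl to 4-methylpiperidin-1-yl can be read: the limit of > 60000 nM in this assay, at which 3 of the 3 values shown sit. The compounds shown leave open whether any change to the shared core gives a measurable value.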